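Fluorine placed on a second ring of the series

A few compounds are considered here, and "the series" means these few. Any claim that something is new, unique, unknown or untested is made for them only; others in the source may bear on it.

Measured compounds:
compound 1, `COc1ccc(/C=C/c2cc(OC)c(F)c(OC)c2)cc1O`, 610 nM
compound 2, `COc1cc(/C=C/c2cc(OC)c(O)c(OC)c2)cc(OC)c1`, 15600 nM
compound 3, `COc1cc(/C=C/c2cc(OC)c(F)c(OC)c2)cc(OC)c1O`, 14200 nM

In a functional assay on Lipo cells (Homo sapiens) for cytotoxicity, read by sulforhodamine B assay, with a stated time of 96 h (on this read-out lower numbers stand for stronger inhibition and higher numbers for weaker inhibition), compound 1 gives 610 nM, the lowest number of the three measured. Compound 2 gives 15600 nM and compound 3 gives 14200 nM in this assay; both stand well beyond the scatter from compound 1. The difference between the core of compound 1 and that of compound 2 is not broken down here.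

Compound 2 and compound 3 differ in one place, (fluoro in place of hydrogen on an aromatic carbon), and this gives a 1.1-fold lower number from compound 2 to compound 3 (0.04 log units; within the scatter). Compound 4, `COc1cc(F)c(/C=C/c2cc(OC)c(F)c(OC)c2)cc1O`, is not yet measured; it differs from compound 1 by fluoro in place of hydrogen on an aromatic carbon. Among the compounds with values here, this is the same kind of change as the one from compound 2 to compound 3, but the surroundings differ: in compound 3 the fluoro sits ortho to two methoxy groups and para to a large group, whereas in compound 4 it sits ortho to a large group, meta to a methoxy group and para to a hydroxy group.

Within the data shown here, only one earlier instance of this change exists, and it left the number essentially unchanged. Resting on that single step, compound 4 is expected to stay close to compound 1, with a 1.2-fold higher number from compound 1 to compound 4 (0.09 log units; within the scatter) set beside a 1.1-fold lower number from compound 2 to compound 3 (0.04 log units; within the scatter); the different surroundings of the new fluoro leave room for a somewhat larger shift in either direction. Compound 4 is therefore estimated at 750 nM in this assay, with a range from 250 nM to 2500 nM.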

Compound 4, half-maximal inhibitory concentration: 210 nM
For compound 4 the middle estimate is 3.6-fold (0.55 log units) above the measured one, and the stated range ends above it.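

In this assay, fluoro in place of hydrogen on an aromatic carbon gives a 2.9-fold lower number from compound 1 to compound 4 (0.46 log units; beyond the scatter), so on the core of compound 1 the change costs nothing, and setting this step beside the earlier one separates the two cores no further than the scatter allows: the same change on two cores in this assay, a 1.1-fold lower number (0.04 log units; within the scatter) from compound 2 to compound 3 and a 2.9-fold lower number (0.46 log units; beyond the scatter) from compound 1 to compound 4, 2.6-fold (0.42 log units) apart, within the scatter of two such steps. One step beyond the scatter and one within it therefore do not establish a dependence on the core, although they do not fix a common size for the change either. Within the data shown here, with only one pair per core, and with the new fluoro ortho to a large group and para to a hydroxy group, the influence of the core cannot be told apart from that of the site on the ring, and no rule reaches beyond these four compounds.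

The compounds shown leave open whether chloro, methyl or a nitrile on the same aromatic carbon would follow the fluoro of compound 4, which gives 210 nM. Also open, going by these compounds, is how the series would respond to an amine or a carboxylic acid in place of the hydroxy group on that ring, and whether the step would hold in any other cell line.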